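Notes on the series: amino in place of chloro

A few compounds are considered here, and "the series" means these few. Any claim that something is new, unique, unknown or untested is made for them only; others in the source may bear on it.

Going by the values given here, compound 2 `Nc1nn(C(=O)Nc2ccc(Cc3ccccc3)cc2)c2ccc(Cl)cc12` is the only member with a numerical reading in a functional assay on SK-OV-3 cells (Homo sapiens) for antiproliferative activity, read by sulforhodamine B assay, with a stated time of 48 h (a lower number here means a stronger inhibitor of growth, a higher number a weaker inhibitor of growth), where compound 2 gives 50500 nM. Compound 1 `Nc1nn(C(=O)Nc2ccc(Cc3ccccc3)cc2)c2ccccc12` carries hydrogen in place of that chloro; in this assay compound 1 reaches only > 100000 nM, which is a limit of the assay and not a number. The step of an at least 1.9-fold lower number from compound 1 to compound 2 (0.29 log units; that floor lies within the scatter) is thus a floor only, and it rests on the limit (the limit of > 100000 nM in this assay, at which 1 of the 2 values shown sits).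

Compound 3 `Nc1ccc2c(c1)c(N)nn2C(=O)Nc1ccc(Cc2ccccc2)cc1` differs from compound 2 by amino in place of chloro on an aromatic carbon. Among the compounds with values here, no measured step concerns an amino group; the one step seen shows that taking the chloro away gives a weaker inhibitor, at the floor stated. With the chloro gone again, compound 3 is expected to come out weaker than compound 2, with an expected step of a 1.8-fold higher number from compound 2 to compound 3 (0.25 log units; within the scatter). Compound 3 is therefore estimated at 90000 nM, within 35000 nM to 250000 nM, and a limit reading is a real possibility.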

Compound 3, concentration for total growth inhibition: 37700 nM
For compound 3 the middle estimate is 2.4-fold (0.38 log units) above the measured one, within the range that was stated.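

Amino and chloro cannot be told apart at this position in this assay: the exchange gives a 1.3-fold lower number from compound 2 to compound 3 (0.13 log units; within the scatter). Amino in place of hydrogen gives an at least 2.6-fold lower number from compound 1 to compound 3 (0.42 log units; beyond the scatter), so with amino on this aromatic carbon the series has its first step beyond the scatter, which the floor for chloro in place of hydrogen did not reach. This step is a floor only, and it rests on a limit: the limit of > 100000 nM in this assay, at which 1 of the 3 values shown sits.

On these data alone, the true size of the step from hydrogen stays open, since only its floor can be read. Also open, as far as these compounds go, is whether a hydroxyl, a methoxy or a carboxylic acid at this position would read like amino and chloro, or would differ from them beyond the scatter.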